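Amino on the thiophene ring: cytotoxicity outlook for compound 4

The source may hold more compounds than are shown below. What is called first, only, known or untested is meant among the compounds shown, and "the series" means these compounds.

Measured so far:
compound 1 `CCOC(=O)c1cc2ccc(Oc3ccnc(C(=O)NC)c3)cc2s1` — > 100000 nM
compound 2 `CNC(=O)c1cc(Oc2ccc3cc(C(=O)OC)sc3c2)ccn1` — 68300 nM
compound 3 `CNC(=O)c1cc(Oc2ccc3cc(C(=O)OC(C)C)sc3c2)ccn1` — 45000 nM

All three values come from an ADME assay on HeLa cells (Homo sapiens) for cytotoxicity, read by MTT assay, with a stated time of 2 days; on this read-out lower numbers stand for higher toxicity in this test and higher numbers for lower toxicity in this test. Among the measured compounds shown here, compound 1 is the only member that gives no number in this assay: it sits at the limit of > 100000 nM in this assay, at which 1 of the 3 values shown sits, a limit of the assay. Compound 2 and compound 3 give numbers, as shown above.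

Compound 4 `CCOC(=O)c1sc2cc(Oc3ccnc(C(=O)NC)c3)ccc2c1N` differs from compound 1 by amino in place of hydrogen on an aromatic carbon.

The measured steps all concern the alkyl on the oxygen next to a carbonyl group, not the aromatic ring: an at least 1.4-fold lower number from compound 1 to compound 2 (0.16 log units; that floor lies within the scatter), an at least 2.2-fold lower number from compound 1 to compound 3 (0.34 log units; beyond the scatter) and a 1.5-fold lower number from compound 2 to compound 3 (0.18 log units; within the scatter). None of them bears on a change at an aromatic carbon, so there is no measured guide for the amino substitution. For the measured compounds named here, with no relevant step, the working expectation is no step beyond the scatter from compound 1 to compound 4, a number no higher from compound 1 to compound 4 (the limit leaves the size open), and a good chance that compound 4 again returns only a limit. The estimated value for compound 4 in this assay is 100000 nM, expected to lie between 40000 nM and 250000 nM.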

Compound 4, half-maximal cytotoxic concentration: 450 nM
Beside the measured number, compound 4's estimate is 220-fold (2.35 log units) above it, outside the stated range (below it).
By their numbers in this assay, from the lowest: compound 4; then compounds 3 and 2 (each within the scatter of the next). At a limit, above all of these: compound 1.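

In this assay, among the compounds shown here, amino in place of hydrogen on the aromatic carbon of the five-membered ring, two ring bonds from the ring sulfur, gives an at least 220-fold lower number from compound 1 to compound 4 (2.34 log units; beyond the scatter) and turns a compound with no measurable cytotoxicity up to the assay's limit into the only clearly toxic member of this set. For the compounds shown here, the changes to the alkyl group gave far smaller steps, with a 1.5-fold lower number from compound 2 to compound 3 (0.18 log units; within the scatter) as the one fully measured example, so this aromatic carbon is the first site where the read-out responds strongly to a change. The size of the new step is only a floor, because compound 1 stands at a limit of the assay and not at a number: the limit of > 100000 nM in this assay, at which 1 of the 4 values shown sits.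

As far as these compounds go, it remains open whether this toxicity belongs to the amino group itself or would also follow from a methylamino, dimethylamino, acetamido or hydroxyl group on the same carbon. Also open, from the compounds shown here alone, is whether amino has the same effect alongside the methyl ester of compound 2, the isopropyl ester of compound 3, or a carboxylic acid in place of the ethoxycarbonyl group.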